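The source may report more compounds than this note shows. Statements on the series, on what has been measured and on what is new or still open speak of the compounds shown alone.

This set of three compounds was examined in an ADME assay on Vero cells (Chlorocebus sabaeus) for cytotoxicity; on this read-out lower numbers stand for higher toxicity in this test and higher numbers for lower toxicity in this test. Compound 1 `O=C(O)c1cccc(-c2ccc(/C=C3\S/C(=N\c4ccc(Cl)cc4)N(c4ccc(Cl)cc4)C3=O)s2)c1` gives > 200000 nM in this assay, a result that is a limit rather than a number. Compound 2 `O=C(O)c1cccc(-c2ccc(/C=C3\S/C(=N\c4ccccc4)N(c4ccc(F)cc4)C3=O)s2)c1` gives > 200000 nM in this assay, again a limit. Compound 3 `O=C(O)c1cccc(-c2ccc(/C=C3\S/C(=N\c4ccccc4)N(c4cccnc4Cl)C3=O)o2)c1` gives > 200000 nM in this assay, also a limit. Among the measured compounds shown here, compound 2 thus stands where every compound of the set stands, as the limit of > 200000 nM in this assay, at which 3 of the 3 values shown sit, shows; no measured step separates it from the others, and nothing more than a limit is known for any of the three.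

Compound 4 `Cc1ncccc1N1C(=O)/C(=C/c2ccc(-c3cccc(C(=O)O)c3)s2)S/C1=N\c1ccccc1` has not yet been measured in this assay. It differs from compound 2 in one place: 2-methylpyridin-3-yl in place of 4-fluorophenyl on an amide-type nitrogen in a ring. The rest of the molecule is kept.

For the measured compounds named here, with no measured step in the set to lean on, the expected step is a number no higher from compound 2 to compound 4 (the limit leaves the size open), which is none beyond the usual scatter. Compound 4 is therefore expected to give about 200000 nM in this assay, with a range from 100000 nM to 400000 nM, and most likely to be reported once more only as a limit.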

Compound 4, half-maximal cytotoxic concentration: > 200000 nM
Compound 4: a limit, no number; the forecaster's own chance of this, stated with the estimate: 85%; the middle value sits exactly at the limit.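

Among the compounds shown here, compound 2 and compound 4 are both reported only as limits in this assay and not as numbers, so putting 2-methylpyridin-3-yl in place of 4-fluorophenyl gives no step that can be read: the limit of > 200000 nM in this assay, at which 4 of the 4 values shown sit.

The compounds shown leave open how far past that limit each of them lies, and so whether the change has any effect at all on the read-out.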